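The compounds below may be only part of what the source reports. "The series", "measured", "known", "first", "only" and "open" are said of these compounds alone.

Measured in an assay on CHO-K1 cells for displacement of a labelled ligand from prostaglandin E2 receptor EP1 subtype (Homo sapiens); on this read-out higher numbers stand for weaker inhibition and lower numbers for stronger inhibition:

- compound 1, `Cc1cc(C(=O)O)nn1Cc1cc(Br)ccc1OCc1ccccc1`: 6.31 nM
- compound 2, `Cc1cc(C(=O)NCc2cccnc2)nn1Cc1cc(Cl)ccc1OCc1ccccc1`: 50.1 nM
- compound 3, `Cc1cc(NC(=O)C2CCCCC2)nn1Cc1cc(Cl)ccc1OCC(C)C`: 31.6 nM

Compound 2 stands at the highest number of the three in this assay. Its nearest neighbour is compound 3, whose number is lower by a margin that lies within the usual scatter of repeated measurements, so the two cannot be ordered. Compound 1 lies furthest off, with a lower number that is beyond the scatter; the acid of compound 1 is the only one of the three to read clearly below the rest.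

Compound 4, `COC(=O)Nc1cc(C)n(Cc2cc(Cl)ccc2OCc2ccccc2)n1`, is not yet measured. It differs from compound 2 in one place:

(methoxycarbonyl)amino in place of ((pyridin-3-yl)methyl)carbamoyl on an aromatic carbon

For the measured compounds named here, no step between measured compounds is available for this change, so the expectation rests on the values alone. Compound 3 carries a (cyclohexanecarbonyl)amino group on the same ring position and reads within the scatter of compound 2, which suggests that a nitrogen-linked carbonyl group on this ring carbon need not move the number far. The step from compound 2 to compound 4 is expected to be small, a 1.7-fold lower number from compound 2 to compound 4 (0.22 log units; within the scatter), in the direction of a lower number but not clearly beyond the scatter. Compound 4 is therefore estimated at 30 nM, with a range from 8 nM to 120 nM.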

Compound 4, half-maximal inhibitory concentration: 200 nM
Estimate against measurement, compound 4: 6.7-fold (0.82 log units) below, and the stated range ends below it.
By their numbers in this assay, from the lowest: compound 1; then compounds 3 and 2 (each within the scatter of the next); then compound 4.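

For the compounds shown here, exchanging ((pyridin-3-yl)methyl)carbamoyl for (methoxycarbonyl)amino on this aromatic carbon of the five-membered ring gives a 4.0-fold higher number from compound 2 to compound 4 (0.60 log units; beyond the scatter) in this assay and is the first single-place change, showing that the number at this position depends on the group carried there. The step comes with equal counts on both sides, 1 hydrogen-bond donor and 2 hydrogen-bond acceptors, while the group falls from 10 heavy atoms to 5 and the six-membered aromatic ring with 1 hetero atom leaves, so matching those counts does not keep the number in place. Nothing available bears on why the number moves with this change.

Going by these compounds alone, the single step also bundles the loss of the ring, the shorter group and the change from a carbon-linked to a nitrogen-linked carbonyl, and these remain inseparable. Open questions are whether a benzylcarbamoyl group, which would keep a ring but no ring nitrogen, or a simple methyl carbamoyl group on this carbon, with the rest of compound 2 unchanged, would stay close to compound 2 or move towards compound 4.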